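Piperidine for methylpiperazine on a second chloro core

The source may hold more compounds than are shown below. What is called first, only, known or untested is meant among the compounds shown, and "the series" means these compounds.

Three compounds carry the same hydroxamic acid aryl group on a fused two-ring core. Compound 1 `COc1cc(OC)c2c(N3CCN(C)CC3)nc(-c3ccc(C(=O)NO)cc3)nc2c1` gives 78.3% in an assay on isolated protein for inhibition of protein deacetylase HDAC6 (Homo sapiens), tested at 0.5 uM; a higher number here means more inhibition at the concentration tested (going by the name of the read-out), a lower number less inhibition. Compound 2 `COc1cc(OC)c2c(N3CCC(F)(F)CC3)nc(-c3ccc(C(=O)NO)cc3)nc2c1` gives 53.2% in this assay. The change between them, (4,4-difluoropiperidin-1-yl in place of 4-methylpiperazin-1-yl on an aromatic carbon), brings a step of a number 25.1 percentage points lower from compound 1 to compound 2 (beyond the scatter). Compound 3 `CN1CCN(c2nc(-c3ccc(C(=O)NO)cc3)nc3cc(Cl)ccc23)CC1` has a core that differs from that of compound 1 in a way not broken down here; in this assay compound 3 gives 94.4%, the highest of the three. Compound 4 `O=C(NO)c1ccc(-c2nc(N3CCC(F)(F)CC3)c3ccc(Cl)cc3n2)cc1` is not yet measured; it stands to compound 3 as compound 2 stands to compound 1, through (4,4-difluoropiperidin-1-yl in place of 4-methylpiperazin-1-yl on an aromatic carbon). The place is the same kind of place as before, described around it as meta to a large group where compound 1 had the 4-(hydroxycarbamoyl)phenyl group; the change is the same kind of change, not the same. Among the compounds with values here, a step of about the earlier size is expected, because a number 25.1 percentage points lower from compound 1 to compound 2 (beyond the scatter) is the only measured instance of this swap and compound 3 starts from 94.4%. The expected step is a number 24.4 percentage points lower from compound 3 to compound 4 (beyond the scatter), with compound 4 estimated at 70%, between 50% and 88%.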

Compound 4, a percentage reported as inhibition, at one concentration (the size of the read-out at that concentration, not a potency): 64.6%
For compound 4 the middle estimate is 5.4 percentage points above the measured one; the measured number falls inside the stated range.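

In this assay, placing 4,4-difluoropiperidin-1-yl where 4-methylpiperazin-1-yl stood gives a number 29.8 percentage points lower from compound 3 to compound 4 (beyond the scatter). The swap therefore carries over from one core to the other in direction and in size: the same change on two cores in this assay, a number 25.1 percentage points lower (beyond the scatter) from compound 1 to compound 2 and a number 29.8 percentage points lower (beyond the scatter) from compound 3 to compound 4, 4.7 percentage points apart, within the scatter of two such steps

This rests on two pairs of compounds, read as inhibition at a single concentration, so it shows neither that the step would hold on a further core nor how potency changes. The compounds shown leave open how a morpholine, an unsubstituted piperidine or an open-chain amine such as dimethylamino would read at this place, so the step cannot yet be tied to the ring nitrogen that leaves or to the fluorines that enter. Also open, from the compounds shown here alone, is whether the step stays the same size with other groups on the shared core, such as a methoxy or a nitrile in place of the chlorine of compound 4.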